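A few compounds are considered here, and "the series" means these few. Any claim that something is new, unique, unknown or untested is made for them only; others in the source may bear on it.

In a functional assay on HCT-15 cells (Homo sapiens) for inhibition, read by MTT assay, with a stated time of 72 h (on this read-out lower numbers stand for stronger inhibition and higher numbers for weaker inhibition), compound 1 (`CNCc1c(OC)cc(Oc2cccc(Nc3ccccc3)c2)cc1OC`) stands at 8930 nM and compound 2 (`COc1cc(Oc2cccc(Nc3ccccc3)c2)cc(OC)c1CNCCNC(C)=O`) at 5090 nM while compound 3 (`COc1ccc(CCCNCc2c(OC)cc(Oc3cccc(Nc4ccccc4)c3)cc2OC)cc1`) gives 730 nM as the lowest of the three numbers. The change to compound 4 (`COc1cc(Oc2cccc(Nc3ccccc3)c2)cc(OC)c1CN(C)C`) is dimethylamino in place of (3-(4-methoxyphenyl)propyl)amino on a saturated chain carbon bound to an aromatic carbon and no value exists for it yet. Read in reverse, a 12-fold lower number from compound 1 to compound 3 (1.09 log units; beyond the scatter) and a 7.0-fold lower number from compound 2 to compound 3 (0.84 log units; beyond the scatter) bear on this change, whereas a 1.8-fold lower number from compound 1 to compound 2 (0.24 log units; within the scatter) stays within the scatter. Among the measured compounds shown here, compound 1 at 8930 nM is the closest measured analogue, so a large step to a higher number is expected in this assay even though no measured compound carries dimethylamino. The estimated step is an 11-fold higher number from compound 3 to compound 4 (1.04 log units; beyond the scatter) on this basis. Compound 4 is expected at 8000 nM with 3500 nM to 18000 nM as the estimated range.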

Compound 4, half-maximal inhibitory concentration: 15600 nM
Compound 4: middle estimate off by 2.0-fold (0.29 log units), on the low side; the measured number falls inside the stated range.
By their numbers in this assay, from the lowest: compound 3; then compounds 2, 1 and 4 (each within the scatter of the next, the first and the last beyond it).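

In this assay, the new compound shows that the short dimethylamino group gives none of the advantage seen with the larger (3-(4-methoxyphenyl)propyl)amino group (a 21-fold higher number from compound 3 to compound 4 (1.33 log units; beyond the scatter)). Against (2-acetamidoethyl)amino the step is smaller (a 3.1-fold higher number from compound 2 to compound 4 (0.49 log units; beyond the scatter)), while methyl in place of hydrogen on an amine nitrogen stays within the scatter (a 1.7-fold higher number from compound 1 to compound 4 (0.24 log units; within the scatter)). No evidence here explains these steps.

Open, going by these compounds, is whether the methoxy group matters, which a plain phenyl or a 4-fluorophenyl at the chain end would test. Also open, on these data alone, is how a piperidine or morpholine would compare with dimethylamino.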